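The source may hold more compounds than are shown below. What is called first, only, known or untested is meant among the compounds shown, and "the series" means these compounds.

Measured compounds:
- compound 1 `CCCSc1nc(N/N=C(\C)c2ccccc2O)c2nnn(Cc3ccc(Cl)cc3)c2n1`: 7100 nM
- compound 2 `CCCSc1nc(N/N=C(\C)c2ccccc2O)c2nnn(Cc3ccccc3)c2n1`: 2310 nM

In a functional assay on MGC-803 cells (Homo sapiens) for antiproliferative activity, read by MTT assay, with a stated time of 72 h (a higher number here means a weaker inhibitor, a lower number a stronger inhibitor), compound 2 gives the lower of the two numbers; compound 1, its nearest neighbour, sits higher by a 3.1-fold lower number from compound 1 to compound 2 (0.49 log units; beyond the scatter) in the other direction, read as hydrogen in place of chloro on an aromatic carbon.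

Compound 3 `CCCSc1nc(N/N=C(\C)c2ccccc2O)c2nnn(Cc3ccc(Br)cc3)c2n1` is not yet measured. It differs from compound 2 by bromo in place of hydrogen on an aromatic carbon. Within the data shown here, the only step that bears on this change is the one from chloro to hydrogen at the same place, a 3.1-fold lower number from compound 1 to compound 2 (0.49 log units; beyond the scatter); a second halogen entering where the first one left is expected to run against that step, and a step of similar size is therefore expected.

Compound 3 is estimated at 6000 nM in this assay, within 2500 nM to 15000 nM, the expected step from compound 2 being a 2.6-fold higher number from compound 2 to compound 3 (0.41 log units; beyond the scatter).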

Compound 3, half-maximal inhibitory concentration: 11300 nM
Compound 3: the middle estimate sits 1.9-fold (0.27 log units) below what was measured, within the range that was stated.
By their numbers in this assay, from the lowest: compound 2; then compounds 1 and 3 (each within the scatter of the next).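

In this assay, a second halogen at this place on the benzyl group also goes against the unsubstituted ring, with a 4.9-fold higher number from compound 2 to compound 3 (0.69 log units; beyond the scatter), so among these three compounds the hydrogen of compound 2 gives the lowest number. Exchanging one halogen for the other gives a 1.6-fold higher number from compound 1 to compound 3 (0.20 log units; within the scatter), so compounds 1 and 3 cannot be told apart here, and in this small set the presence of a halogen matters more than which halogen it is. Nothing available here explains the effect of either halogen.

As far as these compounds go, it remains open whether 4-fluorobenzyl, 4-methoxybenzyl or 4-aminobenzyl would sit with compound 2 or with compounds 1 and 3. Also open, from the compounds shown here alone, is whether the same steps would hold if a longer chain replaced the propyl chain on sulfur.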